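Stability after changing the group on the carbonyl carbon

The compounds below may be only part of what the source reports. "The series", "measured", "known", "first", "only" and "open" are said of these compounds alone.

Three compounds have results so far in an ADME assay on microsomes from liver (Homo sapiens) for metabolic stability, read by LC-MS, with a stated time of 30 min, tested at 1 uM (on this read-out lower numbers stand for a less stable compound and higher numbers for a more stable compound), and they read as follows.

Compound 1 `O=C(NCc1ccc(S(=O)(=O)c2ccccc2C(F)(F)F)cc1)c1cc2cnccc2[nH]1` (52%)
Compound 2 `O=C(NCc1ccc(S(=O)(=O)c2cccc(C(F)(F)F)c2)cc1)c1cc2cnccc2[nH]1` (81%)
Compound 3 `O=C(NCc1ccc(S(=O)(=O)c2cc(F)cc(F)c2)cc1)c1cc2cnccc2[nH]1` (82%)

Compound 2 stands at the high end of these numbers, level with compound 3 and clear of compound 1. All three measured steps swap the group on the sulfonyl sulfur. Two of them are modest (a number 29 percentage points higher from compound 1 to compound 2 (beyond the scatter) and a number 30 percentage points higher from compound 1 to compound 3 (beyond the scatter)), while the third shows no real difference (a number 1 percentage points higher from compound 2 to compound 3 (within the scatter)).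

Compound 4 `O=C(NCc1ccc(S(=O)(=O)c2cccc(C(F)(F)F)c2)cc1)c1cnc2nccn2c1` keeps the sulfonyl side of compound 2 and changes the group on the carbonyl carbon (a group of 9 heavy atoms (6 carbon, 3 nitrogen; one five-membered aromatic ring with 2 hetero atoms, one six-membered aromatic ring with 2 hetero atoms) in place of a group of 9 heavy atoms (7 carbon, 2 nitrogen; one five-membered aromatic ring with 1 hetero atom, one six-membered aromatic ring with 1 hetero atom), on a carbonyl carbon). For the measured compounds named here, no measured step touches that group, so none gives a direct guide to the size or direction of this change. Going by the values given here, they show only that a single swap can shift the number modestly or leave it unchanged.

The best anchor is therefore compound 2 at 81% and so high a starting number leaves more room to fall than to rise. The expected change is small (a number 6 percentage points lower from compound 2 to compound 4 (within the scatter)) and a slight fall is the likelier direction. The estimate for compound 4 is 75% as a central value, with an expected range from 55% to 90% at its ends.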

Compound 4, percent of the compound remaining: 41%
Estimate against measurement, compound 4: 34 percentage points above; the whole stated range lies above it.
By their numbers in this assay, from the lowest: compound 4; then compound 1; then compounds 2 and 3 (each within the scatter of the next).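

The group on the carbonyl carbon turns out to be a sensitive spot in this assay: with the sulfonyl side held fixed, swapping it gives a number 40 percentage points lower from compound 2 to compound 4 (beyond the scatter) and counts as a large step, whereas the swaps on the sulfonyl sulfur were modest or within the scatter. The size of the group, as a count, does not separate the two compounds, since both groups hold 9 heavy atoms; what differs is the make-up, with 6 carbon and 3 nitrogen entering for 7 carbon and 2 nitrogen, and 0 hydrogen-bond donors and 3 hydrogen-bond acceptors entering for 1 hydrogen-bond donor and 1 hydrogen-bond acceptor. These differences all arrive together in this one swap, and nothing measured here shows which of them goes with the lower number.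

The compounds shown leave open where a simpler group on the carbonyl carbon, such as a phenyl or a cyclohexyl, would fall on this scale. They also leave open whether the same swap gives a step of similar size when 3,5-difluorophenyl sits on the sulfonyl sulfur.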